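From Methyl to Methoxy on the Shared Core

The source may report more compounds than this note shows. Statements on the series, on what has been measured and on what is new or still open speak of the compounds shown alone.

Of the compounds shown here, three with one shared core have been measured in a functional assay on PC-3 cells (Homo sapiens) for antiproliferative activity; a lower number here means a stronger inhibitor, a higher number a weaker inhibitor. Compound 1 `C/C(=N\Nc1nc(-c2ccc(Br)cc2)cs1)c1cc2ccccc2o1` gives 45200 nM. Compound 2 `C/C(=N\Nc1nc(-c2ccc(Cl)cc2)cs1)c1cc2ccccc2o1` gives 38100 nM, and compound 3 `C/C(=N\Nc1nc(-c2ccc(C)cc2)cs1)c1cc2ccccc2o1` gives 21400 nM; its step from compound 1 is beyond the scatter, while its gap to compound 2 is within it. The steps of a 1.2-fold lower number from compound 1 to compound 2 (0.07 log units; within the scatter) and a 1.8-fold lower number from compound 2 to compound 3 (0.25 log units; within the scatter) both stayed within the scatter, and only a 2.1-fold lower number from compound 1 to compound 3 (0.32 log units; beyond the scatter) was modest. Compound 4 `COc1ccc(-c2csc(N/N=C(\C)c3cc4ccccc4o3)n2)cc1` differs from compound 3 by methoxy in place of methyl on an aromatic carbon. Among the measured compounds shown here, no measured step involves a methoxy group, so the earlier steps bear only loosely on this one; all three exchange one group at the same place and gave little movement. The number for compound 4 is therefore expected to stay close to that of compound 3, with an expected step of a 1.1-fold lower number from compound 3 to compound 4 (0.03 log units; within the scatter) that is not clearly beyond the scatter. The estimate for compound 4 is 20000 nM, with a range from 8000 nM to 50000 nM.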

Compound 4, half-maximal inhibitory concentration: 28900 nM
Estimate against measurement, compound 4: 1.4-fold (0.16 log units) below; the measured number falls inside the stated range.
By their numbers in this assay, from the lowest: compounds 3, 4, 2 and 1 (each within the scatter of the next, the first and the last beyond it).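

In this assay, going from 4-methylphenyl to 4-methoxyphenyl puts an oxygen and a hydrogen-bond acceptor at this place, yet a 1.4-fold higher number from compound 3 to compound 4 (0.13 log units; within the scatter) stays within the scatter. The methoxy group is not separated from the chloro or bromo groups either, with a 1.3-fold lower number from compound 2 to compound 4 (0.12 log units; within the scatter) and a 1.6-fold lower number from compound 1 to compound 4 (0.19 log units; within the scatter). This position therefore tolerates a fourth group with no clear shift in the number, though nothing available explains this. On these data alone, whether an amine, a carboxylic acid or a longer chain here would move the number further remains open. So does whether this flat response would hold if the shared core changed elsewhere.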